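The source may report more compounds than this note shows. Statements on the series, on what has been measured and on what is new or still open speak of the compounds shown alone.

Measured so far:
- compound 1, `CSCc1ccc(-c2cnc(C(=O)CCCCCCc3ccccc3)o2)nc1`, in an assay for inhibition of Fatty-acid amide hydrolase 1 (Rattus norvegicus), using a Dixon plot; a higher number here means a weaker inhibitor, a lower number a stronger inhibitor: 11.1 nM
- compound 2, `CSC(=O)CCCCc1cnc(C(=O)CCCCCCc2ccccc2)o1`, in this assay: 1.8 nM

Compound 2 has the lowest number of the two in this assay, and its gap to compound 1 lies beyond the scatter: the step from compound 1 to compound 2 was a 6.2-fold lower number from compound 1 to compound 2 (0.79 log units; beyond the scatter). The new compound, compound 3, `N#CCCCCCc1cnc(C(=O)CCCCCCc2ccccc2)o1`, keeps the core of compound 2 and changes only the end of the chain: cyanomethyl in place of (methylsulfanyl)carbonyl on a saturated chain carbon, four bonds along the chain from an aromatic carbon. Within the data shown here, no measured step touches this position; the only step seen, from compound 1 to compound 2, exchanged a different group, a ring for a chain, and gives no guide to swapping one chain end for another. So the expectation rests on compound 2 alone. A change this small at a chain end is expected to move this assay by at most a modest amount, if anything, and the direction is open; a slight rise is taken as the middle guess. Compound 3 is therefore estimated at 4 nM, within 1.2 nM to 15 nM, which would mean an expected step of a 2.2-fold higher number from compound 2 to compound 3 (0.35 log units; beyond the scatter).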

Compound 3, inhibition constant: 4.8 nM
For compound 3 the middle estimate is 1.2-fold (0.08 log units) below the measured one; the measured number falls inside the stated range.
By their numbers in this assay, from the lowest: compound 2; then compound 3; then compound 1.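

Swapping the (methylsulfanyl)carbonyl end of the chain for cyanomethyl gives, in this assay, a 2.7-fold higher number from compound 2 to compound 3 (0.43 log units; beyond the scatter), which shows that this position responds to what sits at the chain end, though only modestly, since two quite different end groups stay fairly close. The chain ending in cyanomethyl also keeps an advantage over the ring-bearing group of compound 1, with a 2.3-fold lower number from compound 1 to compound 3 (0.36 log units; beyond the scatter), so both chains now seen on that aromatic carbon give lower numbers than that group, with the sulfur-containing chain end of compound 2 giving the lowest number of the three. No measurement at hand accounts for the difference between these two chain ends.

Among these compounds, whether a carboxylic acid, an amide or an amine at the end of the chain would push the number lower or higher remains open, since only two end groups can be compared here. Also open, as far as these compounds go, is how much the length of the chain matters, for instance whether a longer chain than 4-cyanobutyl carrying the same nitrile would keep, lose or improve on this result.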